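Exchanging a Chain Methoxy for a Nitrile

The source may report more compounds than this note shows. Statements on the series, on what has been measured and on what is new or still open speak of the compounds shown alone.

Three measured compounds share one core and differ in the group carried on a saturated chain carbon, two bonds along the chain from an oxygen on a saturated carbon. Compound 1 `CCSC[C@@](O)([C@@H](Nc1cccc2nc(C)ccc12)c1ccc(OC)cc1F)C(F)(F)F` carries an ethylsulfanyl group there, compound 2 `COc1ccc([C@H](Nc2cccc3nc(C)ccc23)[C@](O)(CSC)C(F)(F)F)c(Cl)c1F` a methylsulfanyl group and compound 3 `COC[C@@](O)([C@@H](Nc1cccc2nc(C)ccc12)c1ccc(OC)c(F)c1Cl)C(F)(F)F` a methoxy group.

In a functional assay on THP-1 cells (Homo sapiens) (a lower number here means a smaller maximal response, a higher number a larger maximal response), compound 1 gives 85%. In this assay compound 2 gives 98%, and compound 3 gives 97%. Compound 3 stands second highest of the three; it lies within the scatter of compound 2, as shown by a number 1 percentage points lower from compound 2 to compound 3 (within the scatter), whereas the gap to compound 1 is beyond the scatter.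

Compound 4 `COc1ccc([C@H](Nc2cccc3nc(C)ccc23)[C@](O)(CC#N)C(F)(F)F)c(Cl)c1F` differs from compound 3 by cyano in place of methoxy on a saturated chain carbon, two bonds along the chain from an oxygen on a saturated carbon. For the measured compounds named here, the only measured step at that place, a number 1 percentage points lower from compound 2 to compound 3 (within the scatter), was flat, and no measured compound carries a cyano group, so the expectation rests on that flat step and on the near-ceiling values of compounds 2 and 3. Compound 4 is therefore expected to give about 94% in this assay, with a likely range from 80% to 102%. The estimated step is a number 3 percentage points lower from compound 3 to compound 4 (within the scatter), which is expected to remain within the scatter.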

Compound 4, largest response reached (Emax), in percent of the reference or control that the assay uses in the THP-1 assay: 83%
Estimate against measurement, compound 4: 11 percentage points above, and the stated range covers the measured number.
By their numbers in the THP-1 assay, from the lowest: compounds 4 and 1 (each within the scatter of the next); then compounds 3 and 2 (each within the scatter of the next).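

The flat step between methylsulfanyl and methoxy had suggested a tolerant position, but the nitrile shows that this saturated chain carbon does not accept every small group alike: in the THP-1 assay, cyano gives a number 14 percentage points lower from compound 3 to compound 4 (beyond the scatter), and against the methylsulfanyl group it gives a number 15 percentage points lower from compound 2 to compound 4 (beyond the scatter). The change also shifts a second read-out, as in a physicochemical assay for lipophilicity (a higher number here means a more lipophilic compound, a lower number a more polar compound), compound 3 gives 3.8 and compound 4 gives 3.4. Exchanging methoxy for cyano thus leaves a less lipophilic compound as well as a smaller maximal response, although a single pair shows only that the two shifts occur together and not that one follows from the other: the measured partition coefficient of compound 3, 3.8, and of compound 4, 3.4, a number 0.40 log units lower (beyond the scatter)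

The compounds shown do not separate an effect of the nitrile itself from the accompanying fall in partition coefficient, and no other group at this place carries both read-outs here. Also open, on these data alone, is how a primary amide, a hydroxy group or a longer chain ending in a nitrile would behave on the same carbon, and whether maximal response would follow partition coefficient across such groups.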